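This account rests on a few compounds, and the source may have more. Where it says the series, first, only, none or still open, it means among the compounds named here.

Compound 1 `N#C[Se]c1ccc(NC(=O)OCc2ccccc2)cc1` is the starting point of this note. In a physicochemical assay, with a stated time of 180 min, tested at 0.5 mg/mL (a lower number here means less inhibition, a higher number more inhibition at the concentration tested (going by the name of the read-out)), compound 1 gives 3.7%, the lowest of the two numbers in hand. Among the compounds with values here, the only other measured compound, compound 2 `C=CCOC(=O)Nc1ccc([Se][Se]c2ccc(NC(=O)OCC=C)cc2)cc1`, gives 30% in this assay; its structure differs from compound 1 in more than one place, so that gap says nothing about any single change. Compound 3 `CCCCOC(=O)Nc1ccc([Se]C#N)cc1` is not yet measured. It differs from compound 1 by propyl in place of phenyl on a saturated chain carbon bound to an oxygen next to a carbonyl group. The measured pair gives no guide to this change, so the step is expected to stay within the scatter: a number 2.3 percentage points higher from compound 1 to compound 3 (within the scatter). For compound 3 the expected value is 6%, within 0% to 18%.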

Compound 3, a percentage reported as inhibition, at one concentration (the size of the read-out at that concentration, not a potency): 6.6%
Compound 3: middle estimate off by 0.6 percentage points, on the low side; low and high end bracket the measured number.
By their numbers in this assay, from the lowest: compounds 1 and 3 (each within the scatter of the next); then compound 2.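

On a saturated chain carbon bound to an oxygen next to a carbonyl group, propyl in place of phenyl gives a number 2.9 percentage points higher from compound 1 to compound 3 (within the scatter) in this assay. Within the data shown here, this is the first single-place step, and it shows that the number is level across the exchange of the phenyl ring for an open chain, for this one pair. No measurement at hand offers an explanation for this result.

As far as these compounds go, whether a longer chain, an amine or a carboxylic acid at this place would hold the number near compound 1 remains open. The gap to compound 2 spans more than one place and stays unassigned.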